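The source may report more compounds than this note shows. Statements on the series, on what has been measured and on what is new or still open speak of the compounds shown alone.

Working notes on the series. Compound 1 `Cc1ccc(C2CNN=C2S(=O)(=O)CC2=NCCS2)cc1` and compound 3 `Cc1ccc(C2CNN=C2S(=O)(=O)CC2=NCCO2)cc1` share one core; compound 2 `Cc1ccc(-c2c[nH]nc2S(=O)(=O)CC2=NCCS2)cc1` and compound 4 `Cc1ccc(-c2c[nH]nc2S(=O)(=O)CC2=NCCO2)cc1` share another, and the difference between the two cores is not broken down here. In a functional assay, tested at 100 ug/mL (a higher number here means a stronger effect of the compound at the concentration tested, a lower number a weaker effect), compound 1 gives 45.1% and compound 3 gives 46.8%. The step of a number 1.7 percentage points higher from compound 1 to compound 3 (within the scatter) thus comes from the change (a group of 5 heavy atoms (3 carbon, 1 nitrogen, 1 oxygen; one five-membered non-aromatic ring with 2 hetero atoms) in place of a group of 5 heavy atoms (3 carbon, 1 nitrogen, 1 sulfur; one five-membered non-aromatic ring with 2 hetero atoms), on a saturated chain carbon bound to a sulfonyl sulfur).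

In this assay compound 2 is reported as "not active" (no number reported), with no number given. Going by the values given here, compound 4 carries the change (a group of 5 heavy atoms (3 carbon, 1 nitrogen, 1 oxygen; one five-membered non-aromatic ring with 2 hetero atoms) in place of a group of 5 heavy atoms (3 carbon, 1 nitrogen, 1 sulfur; one five-membered non-aromatic ring with 2 hetero atoms), on a saturated chain carbon bound to a sulfonyl sulfur), the same kind of change as the one from compound 1 to compound 3, made on the second core.

For compound 2 to compound 4 a step of similar size is expected in this assay, resting on the step of a number 1.7 percentage points higher from compound 1 to compound 3 (within the scatter) between compound 1 and compound 3, which lies within the scatter. Since compound 2 shows no activity, compound 4 is expected to stay near the inactive end as well, and it is likely that only an inactive result and no number will be reported for compound 4.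

For compound 4 the estimate in this assay is 5%, with an expected range from 0% to 20%.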

Compound 4, a percentage reported as activity, at one concentration (the size of the read-out at that concentration, not a potency): 65.5%
For compound 4 the middle estimate is 60.5 percentage points below the measured one, and the stated range ends below it.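

No step can be read from compound 2 to compound 4 in this assay: compound 4 gives 65.5%, while compound 2 carries only the report "not active", without a number. The compounds shown leave open whether the same change of group has a different effect on the two cores. No data given here bear on this result.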